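The source may report more compounds than this note shows. Statements on the series, on what has been measured and on what is new or still open speak of the compounds shown alone.

Measured in a functional assay on MCF7 cells (Homo sapiens) for cytotoxicity; a lower number here means a stronger inhibitor, a higher number a weaker inhibitor:
- compound 1 `CS(=O)(=O)c1ccc2nc(NC(=O)CCCCCCC(=O)NO)sc2c1`: 15.4 ug/mL
- compound 2 `Cc1ccc2nc(NC(=O)CCCCCCC(=O)NO)sc2c1`: 1.6 ug/mL
- compound 3 `Cc1ccc2nc(NC(=O)CCCCC(=O)NO)sc2c1`: 4.27 ug/mL

Of these three, compound 2 gives the lowest number, 1.6 ug/mL. Compound 4 `CCOc1ccc2nc(NC(=O)CCCCCCC(=O)NO)sc2c1` keeps its chain but has ethoxy in place of methyl on an aromatic carbon. The step that bears most directly is a 9.6-fold lower number from compound 1 to compound 2 (0.98 log units; beyond the scatter), which also exchanges a group on an aromatic carbon. The chain step, a 2.7-fold higher number from compound 2 to compound 3 (0.43 log units; beyond the scatter), bears little, since that chain stays unchanged. Among the measured compounds shown here, no measured compound carries ethoxy, so the direction is uncertain. A modest rise in this assay is expected, hardly beyond the scatter. The expected change is a 1.6-fold higher number from compound 2 to compound 4 (0.19 log units; within the scatter). Compound 4 is estimated at 2.5 ug/mL, within a range of 0.9 ug/mL to 7 ug/mL.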

Compound 4, half-maximal inhibitory concentration: 11.6 ug/mL
For compound 4 the middle estimate is 4.6-fold (0.67 log units) below the measured one; measured number outside the range, above it.
By their numbers in this assay, from the lowest: compound 2; then compound 3; then compounds 4 and 1 (each within the scatter of the next).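

In this assay, the aromatic carbon of the shared core proves intolerant of a second replacement for methyl, not only of methylsulfonyl (a 7.3-fold higher number from compound 2 to compound 4 (0.86 log units; beyond the scatter)). Ethoxy and methylsulfonyl, different as they are, give numbers that cannot be told apart (a 1.3-fold lower number from compound 1 to compound 4 (0.12 log units; within the scatter)), so among the three groups at this place, only methyl gives the low number. No measurement at hand accounts for this result. Open, going by these compounds, is whether methoxy, a chlorine atom or an amine at this place would stay near methyl, and whether ethoxy would act alike on the shorter chain of compound 3.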